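The source may report more compounds than this note shows. Statements on the series, on what has been measured and on what is new or still open speak of the compounds shown alone.

Compound 1, `CNC(=O)c1cc(C(=O)NC2CC2)cn(Cc2cccc(OC)c2)c1=O`, is the most lipophilic of the three measured compounds in a physicochemical assay for lipophilicity, at pH 7.4 (on this read-out lower numbers stand for lower lipophilicity and higher numbers for higher lipophilicity), where compound 1 gives 3. Compound 3, `CNC(=O)c1cc(C(=O)NC)c(=O)n(Cc2ccccc2)c1`, gives 2.4, and compound 2, `CNC(=O)c1cc(C(=O)NCCO)cn(Cc2ccccc2)c1=O`, gives 1.9, the lowest of the set. Going by the values given here, the only single-point step among the measured compounds is a number 0.50 log units higher from compound 2 to compound 3 (beyond the scatter), and it goes with the loss of a hydrogen-bond donor. Compound 4, `CNC(=O)c1cc(C(=O)NC2CC2)cn(Cc2cccc3c2CCN3)c1=O`, differs from compound 1 in one place: 2,3-dihydro-1H-indol-4-yl in place of 3-methoxyphenyl on a saturated chain carbon bound to an aromatic nitrogen. Among the compounds with values here, the group that enters carries one hydrogen-bond donor where the group that leaves carries none, so the step from compound 2 to compound 3 bears on it only by analogy and in the opposite sense; no measured step matches this exchange directly. The expectation is therefore a modest fall in this assay, beyond the scatter but smaller than a full unit, giving an estimated a number 0.60 log units lower from compound 1 to compound 4 (beyond the scatter). On that basis compound 4 is expected to show 2.4, with a likely range from 1.8 to 3.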

Compound 4, distribution coefficient: 2.1
For compound 4 the middle estimate is 0.30 log units above the measured one; the measured number falls inside the stated range.
By their numbers in this assay, from the lowest: compounds 2, 4 and 3 (each within the scatter of the next, the first and the last beyond it); then compound 1.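

In this assay, going by these compounds alone, the exchange of 3-methoxyphenyl for 2,3-dihydro-1H-indol-4-yl gives a number 0.90 log units lower from compound 1 to compound 4 (beyond the scatter) on a saturated chain carbon bound to an aromatic nitrogen, the first measured sign that the group at this place moves the read-out, as the only earlier step lay elsewhere. The entering group carries a hydrogen-bond donor and the leaving group none, and this fall runs in the same sense as a number 0.50 log units higher from compound 2 to compound 3 (beyond the scatter) where a donor is lost, though two pairs at two different places establish no rule. No measurement at hand explains the fall.

The compounds shown leave open whether the ring nitrogen of the entering group or its fused ring accounts for the step. An aminophenyl group or an N-methyl indoline group at the same place would separate the two.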